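From a Solubility Limit to a Carbamoyl Analogue

The source may report more compounds than this note shows. Statements on the series, on what has been measured and on what is new or still open speak of the compounds shown alone.

compound 1 `FC(F)(F)c1cccc(-c2nc3cnc(Nc4ncccn4)cc3[nH]2)c1`: 155000 nM
compound 2 `FC(F)(F)c1cccc(-c2nc3cnc(Nc4cccnn4)cc3[nH]2)c1`: 161000 nM
compound 3 `Fc1ccc(Nc2cc3[nH]c(-c4cccc(C(F)(F)F)c4)nc3cn2)nc1`: < 5000 nM

In a physicochemical assay for solubility, using the shake flask method, measured as kinetic solubility, with a stated time of 20 h, at pH 2 (on this read-out higher numbers stand for higher solubility and lower numbers for lower solubility), compound 1 gives 155000 nM and compound 2 gives 161000 nM; the step of a 1.0-fold higher number from compound 1 to compound 2 (0.02 log units; within the scatter) stays within the scatter. Compound 3 returns only a limit of the assay, < 5000 nM, so no number is known for it. Both measured steps leading to it are large: an at least 31-fold lower number from compound 1 to compound 3 (1.49 log units; beyond the scatter) and an at least 32-fold lower number from compound 2 to compound 3 (1.50 log units; beyond the scatter). Compound 3 therefore stands well apart from the other two, sitting at the limit of < 5000 nM in this assay, at which 1 of the 3 values shown sits.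

Compound 4 `NC(=O)c1ccc(Nc2cc3[nH]c(-c4cccc(C(F)(F)F)c4)nc3cn2)nc1` carries the change (carbamoyl in place of fluoro on an aromatic carbon). Going by the values given here, no measured step swaps a substituent on this ring while keeping the ring itself, so the two large steps into compound 3 only show how far the series has fallen, not what this exchange does. With compound 3 already at a limit, a further drop cannot be seen in this assay, and any rise would have to lift compound 4 above that limit to register.

Compound 4 is expected to give about 9000 nM, between 2000 nM and 60000 nM. The step of an at least 1.8-fold higher number from compound 3 to compound 4 (0.25 log units; that floor lies within the scatter) is thus estimated as modest and uncertain, and a second limit remains a real possibility.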

Compound 4, solubility: < 5000 nM
Compound 4: only a limit was reported (the forecaster's own chance of this, stated with the estimate: 40%); at least 1.8-fold (0.25 log units) between middle value and limit.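

In this assay compound 4 returns only a limit of the assay, < 5000 nM, so carbamoyl in place of fluoro on this aromatic carbon, two atoms from the ring nitrogen, still yields no number. The step from compound 3 to compound 4 cannot be read, as both results are limits, and whether the exchange changes anything at this position stays hidden. The large gaps to the pyridazin-3-yl and pyrimidin-2-yl compounds remain, an at least 32-fold lower number from compound 2 to compound 4 (1.50 log units; beyond the scatter) and an at least 31-fold lower number from compound 1 to compound 4 (1.49 log units; beyond the scatter), which now places both the 5-fluoropyridin-2-yl and the 5-carbamoylpyridin-2-yl compounds at the same floor: the limit of < 5000 nM in this assay, at which 2 of the 4 values shown sit.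

From the compounds shown here alone, whether an amine or a carboxylic acid on this aromatic carbon would give a readable number in this assay stays open, as does how far compound 3 and compound 4 truly lie from their shared limit. An unsubstituted pyridin-2-yl ring on the same nitrogen would show whether the ring itself or the group on it goes with the gap to compound 1 and compound 2.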